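The source may report more compounds than this note shows. Statements on the series, on what has been measured and on what is new or still open speak of the compounds shown alone.

Working notes on the series, with three compounds measured so far in a physicochemical assay for lipophilicity, using the shake flask method, at pH 7.4 (a higher number here means a more lipophilic compound, a lower number a more polar compound), on the shared scale. Compound 1 `CCCC(Nc1ccc(-n2cc(C(F)(F)F)cn2)nc1)c1ccc(C(=O)NCCC(=O)O)cc1` gives 2.1 here, compound 3 `CCCC(Nc1cc(C)c(-n2cc(C(F)(F)F)cn2)c(C)c1)c1ccc(C(=O)NCCC(=O)O)cc1` gives 2.2 here, and compound 2 `CCCC(Oc1ccc(-n2cc3ccccc3n2)cc1)c1ccc(C(=O)NCCC(=O)O)cc1` gives 2.5 in the same measurement. Compound 2 thus sits above compound 1, by a gap beyond the usual scatter, whereas compound 2 and compound 3 lie within the scatter of each other. For the measured compounds named here, these three compounds differ from one another in more than one place, so no measured step gives a direct guide to the next change.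

Compound 4 `CCCC(Oc1ccc(-n2cc(C)cn2)cc1)c1ccc(C(=O)NCCC(=O)O)cc1` is still unmeasured. It differs from compound 2 by 4-methyl-1H-pyrazol-1-yl in place of 2H-indazol-2-yl on an aromatic carbon, para to a large group (4-methyl-1H-pyrazol-1-yl in place of 2H-indazol-2-yl on an aromatic carbon). The entering group keeps a five-membered aromatic ring with 2 hetero atoms but has no six-membered aromatic ring of carbon only. On the structural change alone, a moderate fall beyond the scatter is expected. The estimated step in this assay is a number 0.50 log units lower from compound 2 to compound 4 (beyond the scatter) on that reading. For compound 4 the estimated value is 2 with an expected range from 1.6 to 2.4 on this scale.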

Compound 4, distribution coefficient: 2.1
Compound 4: the middle estimate sits 0.10 log units below what was measured, within the range that was stated.
By their numbers in this assay, from the lowest: compounds 1, 4, 3 and 2 (each within the scatter of the next, the first and the last beyond it).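

Within the series, the exchange of 2H-indazol-2-yl for 4-methyl-1H-pyrazol-1-yl on an aromatic carbon, para to a large group, gives the first step that can be read at a single place in this assay, namely a number 0.40 log units lower from compound 2 to compound 4 (beyond the scatter), so the reading at this position does move with the group it carries. The change is a specific one: the five-membered aromatic ring with 2 hetero atoms stays and the six-membered aromatic ring of carbon only goes, with 6 heavy atoms entering in place of 9, while the counts of hydrogen-bond donors and acceptors match and neither group has a net charge. No independent data bear on this step, and its size is recorded here as an observation only.

For the compounds shown here, the single step leaves open how much of the difference goes with the lost six-membered ring and how much with the added methyl, a question that a plain 1H-pyrazol-1-yl at this position would address directly. Also open, from the compounds shown here alone, is how a group such as 4-chloro-1H-pyrazol-1-yl or 4-cyano-1H-pyrazol-1-yl would read at the same place on the shared core.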